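Trimming the side chain: what to expect for compound 3

The source may report more compounds than this note shows. Statements on the series, on what has been measured and on what is new or still open speak of the compounds shown alone.

Compound 1 `O=C1CSC(=O)N1C[C@H]1CN(c2ccc(-n3cc(-c4ccccn4)cn3)c(F)c2)C(=O)O1`: 26900 nM
Compound 2 `CCNC(=O)NC[C@H]1CN(c2ccc(-n3cc(-c4ccccn4)cn3)c(F)c2)C(=O)O1`: 222000 nM

Among the measured compounds shown here, in a physicochemical assay for solubility, read by HPLC, with a stated time of 24 h (on this read-out lower numbers stand for lower solubility and higher numbers for higher solubility), compound 2 gives 222000 nM, the highest of the two numbers measured so far, while compound 1 gives 26900 nM. For the measured compounds named here, the one measured step, an 8.3-fold higher number from compound 1 to compound 2 (0.92 log units; beyond the scatter), shows that exchanging the group on the side chain of the shared core changes solubility by a modest but real amount. Compound 3 `NC(=O)[C@H]1CN(c2ccc(-n3cc(-c4ccccn4)cn3)c(F)c2)C(=O)O1` differs from compound 2 by carbamoyl in place of ((ethylcarbamoyl)amino)methyl on a saturated ring carbon. Going by the values given here, no measured step matches this exact change; the step from compound 1 to compound 2 only indicates that this part of the molecule matters, so a step of comparable size, in either direction, is plausible. Compound 3 is therefore expected to give about 100000 nM, with a likely range from 30000 nM to 300000 nM. That estimate amounts to an expected 2.2-fold lower number from compound 2 to compound 3 (0.35 log units; beyond the scatter).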

Compound 3, solubility: 27200 nM
Compound 3: middle estimate off by 3.7-fold (0.57 log units), on the high side, outside the stated range (below it).
By their numbers in this assay, from the lowest: compounds 1 and 3 (each within the scatter of the next); then compound 2.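

On the saturated ring carbon next to the ring oxygen, putting carbamoyl in place of ((ethylcarbamoyl)amino)methyl in this assay gives an 8.2-fold lower number from compound 2 to compound 3 (0.91 log units; beyond the scatter), so the position responds to this shortening as well as to the exchange seen earlier. Putting the same carbamoyl in place of (2,4-dioxo-1,3-thiazolidin-3-yl)methyl gives a 1.0-fold higher number from compound 1 to compound 3 (0.00 log units; within the scatter), so among these three compounds only compound 2 stands apart, and two quite different groups read alike. Nothing available accounts for why compound 2 stands apart.

The compounds shown leave open which part of the ((ethylcarbamoyl)amino)methyl group goes with the higher number, since no chain here keeps the methylene and urea-type carbonyl while lacking the ethyl end. Going by these compounds, how an amine or a carboxylic acid on this ring carbon would read in this assay also remains open.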